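Two Limits and a Dinitrophenyl Swap on the Triazole

This account rests on a few compounds, and the source may have more. Where it says the series, first, only, none or still open, it means among the compounds named here.

Compound 1 `Cc1ccccc1-n1nncc1CN1C(=O)C2(C(C#N)=C(N)Oc3c(N)cc4nc5ccccc5nc4c32)c2ccccc21` was tested in an ADME assay on L02 cells (Homo sapiens) for antiproliferative activity, read by MTT assay, with a stated time of 48 h (on this read-out higher numbers stand for weaker inhibition and lower numbers for stronger inhibition), and gives > 50000 nM, which is a limit of the assay rather than a number. Compound 2 `CCc1cccc(C)c1-n1nncc1CN1C(=O)C2(C(C#N)=C(N)Oc3c(N)cc4nc5ccccc5nc4c32)c2ccccc21` in this assay likewise gives > 50000 nM, again a limit. The step that the two limits leave unreadable from compound 1 to compound 2 therefore cannot be read; compound 2 sits at the limit of > 50000 nM in this assay, at which 2 of the 2 values shown sit.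

Compound 3 `N#CC1=C(N)Oc2c(N)cc3nc4ccccc4nc3c2C12C(=O)N(Cc1cnnn1-c1ccc([N+](=O)[O-])cc1[N+](=O)[O-])c1ccccc12` differs from compound 2 by 2,4-dinitrophenyl in place of 2-ethyl-6-methylphenyl on an aromatic nitrogen. Going by the values given here, no measured step is readable, so no direction beyond the scatter can be expected; the estimated step of a number no higher from compound 2 to compound 3 (the limit leaves the size open) is near zero. Compound 3 is expected to give 50000 nM, with a range from 20000 nM to 120000 nM.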

Compound 3, half-maximal inhibitory concentration: 22800 nM
Beside the measured number, compound 3's estimate is 2.2-fold (0.34 log units) above it, within the range that was stated.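

In this assay, going by these compounds alone, the group on the aromatic nitrogen is now the first change that can be read: 2,4-dinitrophenyl gives an at least 2.1-fold lower number from compound 2 to compound 3 (0.34 log units; beyond the scatter), and also an at least 2.1-fold lower number from compound 1 to compound 3 (0.34 log units; beyond the scatter). This position can therefore shift the read-out towards stronger inhibition, and compound 3 gives the first real number. The other two values remain limits of the assay: the limit of > 50000 nM in this assay, at which 2 of the 3 values shown sit.

Going by these compounds, the full size of both steps stays open. So does whether a single nitro group, an amine or a carboxylic acid on that phenyl ring would shift the read-out in the same way.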